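This account rests on a few compounds, and the source may have more. Where it says the series, first, only, none or still open, it means among the compounds named here.

Among the compounds with values here, in a functional assay on G-361 cells (Homo sapiens) for inhibition, with a stated time of 72 h (on this read-out higher numbers stand for weaker inhibition and lower numbers for stronger inhibition), compound 1 (`NC1CCC(Nc2nc(NCc3ccc(-c4ccco4)cc3)c3ncn(C4CCCC4)c3n2)CC1`) gives 164 nM and compound 2 (`NC1CCC(Nc2nc(NCc3ccc(-c4ccsc4)nc3)c3ncn(C4CCCC4)c3n2)CC1`) gives 272 nM, so compound 2 stands level with the only other measured number. Within the data shown here, the single measured step, a 1.7-fold higher number from compound 1 to compound 2 (0.22 log units; within the scatter), exchanges 4-(furan-2-yl)phenyl for 6-(thiophen-3-yl)pyridin-3-yl and does not test a group like 2-aminophenyl. Compound 3 (`Nc1ccccc1CNc1nc(NC2CCC(N)CC2)nc2c1ncn2C1CCCC1`) differs from compound 2 on a saturated chain carbon bound to a nitrogen on an aromatic ring: 2-aminophenyl in place of 6-(thiophen-3-yl)pyridin-3-yl on a saturated chain carbon bound to a nitrogen on an aromatic ring. Among the measured compounds shown here, with no measured step covering this change, the expectation is loose: an expected move towards weaker inhibition in this assay, a 2.2-fold higher number from compound 2 to compound 3 (0.34 log units; beyond the scatter). Compound 3 is estimated at 600 nM, within an expected range of 150 nM to 2400 nM.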

Compound 3, half-maximal inhibitory concentration: 2070 nM
For compound 3 the middle estimate is 3.5-fold (0.54 log units) below the measured one; the range from low to high includes it.
By their numbers in this assay, from the lowest: compounds 1 and 2 (each within the scatter of the next); then compound 3.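

At the position on a saturated chain carbon bound to a nitrogen on an aromatic ring, the group does matter in this assay: 2-aminophenyl gives a 7.6-fold higher number from compound 2 to compound 3 (0.88 log units; beyond the scatter) and a 13-fold higher number from compound 1 to compound 3 (1.10 log units; beyond the scatter). The earlier exchange between 4-(furan-2-yl)phenyl and 6-(thiophen-3-yl)pyridin-3-yl stayed within the scatter, whereas both of these steps to 2-aminophenyl lie beyond it. Nothing available explains this shift.

The compounds shown do not separate the effect of the amine on 2-aminophenyl from that of losing the second aromatic ring. A plain phenyl or a 2-hydroxyphenyl at this position would bear on that question.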